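From Amide to Acid on a Short Side Chain

The compounds below may be only part of what the source reports. "The series", "measured", "known", "first", "only" and "open" are said of these compounds alone.

In a functional assay on OVCAR-8 cells (Homo sapiens) for antiproliferative activity (a higher number here means a weaker inhibitor, a lower number a stronger inhibitor), compound 1 (`Cn1ncc(Cl)c1-c1cc(C(=O)N[C@@H]2CN[C@H](CC(O)CO)C[C@H]2c2ccc(Cl)c(Cl)c2)oc1Cl`) gives 1610 nM and compound 2 (`Cn1ncc(Cl)c1-c1cc(C(=O)N[C@@H]2CN[C@H](CCN3CCC(O)CC3)C[C@H]2c2ccc(Cl)c(Cl)c2)oc1Cl`) gives 15900 nM while compound 3 (`Cn1ncc(Cl)c1-c1cc(C(=O)N[C@@H]2CN[C@H](CC(N)=O)C[C@H]2c2ccc(Cl)c(Cl)c2)oc1Cl`) gives 1000 nM on the same scale. Compound 3 thus sits level with compound 1, as a 1.6-fold lower number from compound 1 to compound 3 (0.21 log units; within the scatter) shows, and both stand clear of compound 2.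

Compound 4 (`Cn1ncc(Cl)c1-c1cc(C(=O)N[C@@H]2CN[C@H](CC(=O)O)C[C@H]2c2ccc(Cl)c(Cl)c2)oc1Cl`) has not yet been measured. It differs from compound 3 by a single swap (hydroxy in place of amino on a carbonyl carbon) with hydroxy in place of amino on a carbonyl carbon, which turns carbamoyl to carboxy.

Going by the values given here, no measured pair makes this exact swap, so the nearest guides are the other changes on the same side chain. These gave a 9.9-fold higher number from compound 1 to compound 2 (0.99 log units; beyond the scatter) in one case and a 16-fold lower number from compound 2 to compound 3 (1.20 log units; beyond the scatter) in another, so this part of the molecule can matter. Those steps exchanged whole groups, while this one exchanges one atom, so a smaller step is expected. The direction is a weak call, resting only on the fact that no measured side chain gives a number clearly below that of compound 3.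

The expected change is a 2.5-fold higher number from compound 3 to compound 4 (0.40 log units; beyond the scatter) in this assay as an estimate. For compound 4 the estimated value is 2500 nM with an expected range from 700 nM to 10000 nM for a typical measurement.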

Compound 4, half-maximal inhibitory concentration: 5120 nM
Compound 4: the middle estimate sits 2.0-fold (0.31 log units) below what was measured; measured number inside the range.
By their numbers in this assay, from the lowest: compounds 3 and 1 (each within the scatter of the next); then compound 4; then compound 2.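

In this assay, going by these compounds alone, the earlier steps on this side chain exchanged whole groups, whereas this one shows that replacing a single atom on the carbonyl carbon can also shift the number clearly: a 5.1-fold higher number from compound 3 to compound 4 (0.71 log units; beyond the scatter). The carboxy group also separates from both of the other side chains, with a 3.2-fold higher number from compound 1 to compound 4 (0.50 log units; beyond the scatter) and a 3.1-fold lower number from compound 2 to compound 4 (0.49 log units; beyond the scatter), so compound 4 falls in a middle place, apart from compound 1 and compound 3, which lie within the scatter of each other, and from the much weaker compound 2. Nothing available explains why hydroxy and amino differ here, as no supporting measurement accompanies these numbers.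

The compounds shown leave open whether other replacements on the carbonyl carbon, such as a methyl ester or an N-methyl amide, would stay close to compound 3 or move toward compound 4. They also leave open how the number would respond to a longer chain carrying the carboxy group, or to a primary amine at the end of the same short chain.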